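The compounds below may be only part of what the source reports. "The series", "measured", "known", "first", "only" and "open" are said of these compounds alone.

The series rests on a shared core of a sulfoxide bearing a diphenylmethyl group and an aryl-methyl arm. Compound 1 `COc1ccnc(C[S+]([O-])C(c2ccccc2)c2ccccc2)c1OC` is reported in an assay on HEK293 cells for inhibition of sodium-dependent dopamine transporter (Homo sapiens), read by scintillation counting, with stated times of 5 min and 1 min (a lower number here means a stronger inhibitor, a higher number a weaker inhibitor), as "not active" (no number reported), without a number. Compound 2 `[O-][S+](Cc1cccs1)C(c1ccc(F)cc1)c1ccc(F)cc1` gives in this assay a value of 4000 nM. Compound 3 `[O-][S+](Cc1ccc(Cl)s1)C(c1ccccc1)c1ccccc1` gives in this assay a value of 12800 nM, the highest number among those reported; the gap to compound 2 lies beyond the usual scatter, so compound 3 is the weaker of the two.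

Compound 4 `[O-][S+](Cc1ccsc1Br)C(c1ccccc1)c1ccccc1` differs from compound 3 in one place: 2-bromothiophen-3-yl in place of 5-chlorothiophen-2-yl on a saturated chain carbon bound to a sulfur. Among the compounds with values here, no measured pair in this set shows the effect of moving the halogen and the point of attachment on the thiophene in this way, so nothing known here speaks for a large step in either direction. Compound 4 is therefore expected to sit near compound 3, with the estimated step from compound 3 to compound 4 in this assay being a 1.3-fold lower number from compound 3 to compound 4 (0.11 log units; within the scatter), within the scatter. Compound 4 is estimated at 10000 nM, with a range from 3000 nM to 35000 nM.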

Compound 4, half-maximal inhibitory concentration: 29300 nM
For compound 4 the middle estimate is 2.9-fold (0.47 log units) below the measured one, within the range that was stated.
By their numbers in this assay, from the lowest: compound 2; then compound 3; then compound 4.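

In this assay, replacing 5-chlorothiophen-2-yl with 2-bromothiophen-3-yl on a saturated chain carbon bound to a sulfur gives a 2.3-fold higher number from compound 3 to compound 4 (0.36 log units; beyond the scatter). Within the data shown here, this is the first comparison between compounds that differ in one place, and it shows that this place responds to a change in the thiophene arm, even though both arms have the same count of heavy atoms, hydrogen-bond donors and acceptors. No measured information accounts for the direction or size of this step.

Going by these compounds, the step changes the halogen and the point of attachment together, so the share of each remains open. Also open, on these data alone, is how a nitrile or an aminomethyl group on the thiophene in place of the halogen would read in this assay.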